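The source may hold more compounds than are shown below. What is called first, only, known or untested is meant among the compounds shown, and "the series" means these compounds.

The study rests on two measured compounds. Compound 1, with the structure `N=C(NCCCc1c[nH]cn1)NCCC(c1ccc(Cl)c(Cl)c1)c1ccccn1`, gives 7.54 in a functional assay on muscle tissue for agonist activity at histamine H2 receptor (Cavia porcellus); a higher number here means a more potent compound, by a factor of ten per unit of this negative logarithm, a lower number a less potent compound. Compound 2, with the structure `N=C(NCCCc1c[nH]cn1)NCCC(c1ccccc1)c1ccc(F)cc1`, gives 7.45 in this assay. Compound 2 stands alongside compound 1 on these numbers: the two values lie within the usual scatter of each other, so neither can be set apart from the other.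

The step to compound 3, with the structure `N=C(NCCCc1c[nH]cn1)NCCC(c1ccccc1)c1ccc(Cl)c(Cl)c1`, brings (3,4-dichlorophenyl in place of 4-fluorophenyl on a saturated chain carbon bound to an aromatic carbon and a saturated chain carbon). Within the data shown here, no measured pair shows this change on its own, so its size has to be estimated rather than read off. Since compound 1 carries the same entering group and gives 7.54, a step from compound 2 to compound 3 of about a number 0.15 log units higher from compound 2 to compound 3 (within the scatter) is expected, small and hardly beyond the scatter. Compound 3 is therefore expected to give about 7.6 in this assay, between 7.1 and 8.1.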

Compound 3, negative logarithm of the half-maximal effective concentration: 6.03
For compound 3 the middle estimate is 1.57 log units above the measured one; measured number below the stated range.
By their numbers in this assay, from the lowest: compound 3; then compounds 2 and 1 (each within the scatter of the next).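

Compound 3 shows that this saturated chain carbon is far from indifferent to what it carries, which the close values of compounds 1 and 2 could not reveal. With phenyl as the other group held in place, 3,4-dichlorophenyl in place of 4-fluorophenyl gives a number 1.42 log units lower from compound 2 to compound 3 (beyond the scatter) in this assay, and with 3,4-dichlorophenyl held in place, phenyl in place of pyridin-2-yl gives a number 1.51 log units lower from compound 1 to compound 3 (beyond the scatter), so 3,4-dichlorophenyl goes with high potency only in compound 1, where pyridin-2-yl accompanies it. The data at hand offer no explanation for either drop.

As far as these compounds go, whether the pairing of 4-fluorophenyl with pyridin-2-yl would hold up at this carbon remains open. So does how a methoxy group or an amine on the phenyl ring would fare here.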